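Mirror-Image Primary Amine in Sigma-1 Receptor Binding

The source may hold more compounds than are shown below. What is called first, only, known or untested is meant among the compounds shown, and "the series" means these compounds.

Compound 1 `c1ccc([C@H]2CCC[C@@H](CCN3CCCC3)C2)cc1`: 3.6 nM
Compound 2 `c1ccc(CNCC[C@H]2CCC[C@@H](c3ccccc3)C2)cc1`: 1.3 nM
Compound 3 `NCC[C@H]1CCC[C@@H](c2ccccc2)C1`: 138 nM

In an assay on membranes from brain for displacement of a labelled ligand from Sigma non-opioid intracellular receptor 1 (Cavia porcellus), read by scintillation counting, with a stated time of 120 min (on this read-out lower numbers stand for stronger inhibition and higher numbers for weaker inhibition), compound 3 stands highest of the three numbers; compound 1 lies nearer to it and compound 2 furthest. Among the measured compounds shown here, the one step measured, a 110-fold higher number from compound 2 to compound 3 (2.03 log units; beyond the scatter), came from hydrogen in place of benzyl on an amine nitrogen. Compound 4 `NCC[C@@H]1CCC[C@H](c2ccccc2)C1` is the next step: the two compounds have the same atoms and bonds and differ only in configuration as drawn: 2 of 2 stereo elements differ (all stereocentres are inverted: mirror images); a stereocentre at a saturated ring carbon is drawn S in compound 3 and R in compound 4; a stereocentre at a saturated ring carbon is drawn R in compound 3 and S in compound 4. For the measured compounds named here, no measured step concerns a change of configuration alone, so the step of a 110-fold higher number from compound 2 to compound 3 (2.03 log units; beyond the scatter) does not bear on this change. With nothing in the measured set to point a direction, no step beyond the scatter is expected in this assay, but the range is kept wide. Compound 4 is therefore estimated at 200 nM, between 50 nM and 1000 nM. The step of a 1.4-fold higher number from compound 3 to compound 4 (0.16 log units; within the scatter) is expected to be small.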

Compound 4, inhibition constant: 167 nM
Beside the measured number, compound 4's estimate is 1.2-fold (0.08 log units) above it, within the range that was stated.
By their numbers in this assay, from the lowest: compound 2; then compound 1; then compounds 3 and 4 (each within the scatter of the next).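

In this assay, among the compounds shown here, inverting both stereocentres of the primary amine gave a 1.2-fold higher number from compound 3 to compound 4 (0.08 log units; within the scatter) and so left the number within the scatter, which no earlier compound could show. This comparison isolates configuration: the fact that compounds 3 and 4 differ only in the configuration as drawn. Changing the amine itself remains the large step, with amino in place of pyrrolidin-1-yl giving a 46-fold higher number from compound 1 to compound 4 (1.67 log units; beyond the scatter) in this same comparison. On these data alone, whether configuration matters equally little with benzyl or pyrrolidin-1-yl on the nitrogen stays open. The compounds also leave open how a piperidine on the chain or a longer chain would behave.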